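Alkyl enlargement at the olefinic carbon: isopropyl to cyclohexyl

The source may hold more compounds than are shown below. What is called first, only, known or untested is meant among the compounds shown, and "the series" means these compounds.

Measured so far:
compound 1 `C/C(=C(/c1ccc(/C=C/C(=O)O)cc1)c1ccc2[nH]ncc2c1)c1ccccc1` — 40 nM
compound 2 `CC(C)/C(=C(/c1ccc(/C=C/C(=O)O)cc1)c1ccc2[nH]ncc2c1)c1ccccc1` — 4 nM

For the measured compounds named here, in a functional assay on MCF7 cells (Homo sapiens) for cytotoxicity, read by CellTiter-Glo, with a stated time of 5 days (a higher number here means a weaker inhibitor, a lower number a stronger inhibitor), compound 2 stands lowest of the two numbers; the single measured step, a 10-fold lower number from compound 1 to compound 2 (1.00 log units; beyond the scatter), is beyond the scatter. Compound 3 `O=C(O)/C=C/c1ccc(/C(=C(\c2ccccc2)C2CCCCC2)c2ccc3[nH]ncc3c2)cc1` carries cyclohexyl in place of isopropyl on a double-bonded chain carbon bound to an aromatic carbon and a double-bonded chain carbon. Going by the values given here, the only step that bears on this change is the earlier enlargement at the same position, a 10-fold lower number from compound 1 to compound 2 (1.00 log units; beyond the scatter). A second enlargement at this carbon is expected to give at most a small further lowering, a 1.3-fold lower number from compound 2 to compound 3 (0.12 log units; within the scatter), with broad uncertainty. Compound 3 is therefore estimated at 3 nM, range 1 nM to 12 nM.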

Compound 3, half-maximal inhibitory concentration: 64 nM
The estimate for compound 3 lay 21-fold (1.33 log units) below the measured number, outside the stated range (above it).
By their numbers in this assay, from the lowest: compound 2; then compounds 1 and 3 (each within the scatter of the next).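

In this assay, enlarging the group on this double-bonded chain carbon does not keep lowering the number: cyclohexyl in place of isopropyl gives a clear reversal (a 16-fold higher number from compound 2 to compound 3 (1.20 log units; beyond the scatter)). Cyclohexyl in place of methyl gives no readable change (a 1.6-fold higher number from compound 1 to compound 3 (0.20 log units; within the scatter)), so the gain is confined to isopropyl among these three compounds. No measured evidence accounts for this turn.

Going by these compounds, it remains open whether the ring of cyclohexyl or its heavy-atom count goes with the higher number. Cyclopropyl and tert-butyl at this carbon would separate the two.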